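This account rests on a few compounds, and the source may have more. Where it says the series, first, only, none or still open, it means among the compounds named here.

Measured in a functional assay on MCF7 cells (Homo sapiens) for antiproliferative activity, read by MTT assay, with a stated time of 48 h; on this read-out higher numbers stand for weaker inhibition and lower numbers for stronger inhibition:

- compound 1 `CCCCCCCCCn1cc(COC[C@@H]2OC[C@H](N)[C@@H]2O)nn1`: 12400 nM
- compound 2 `CCCCCCCCCCCCCCCCCCn1cc(COC[C@@H]2OC[C@H](N)[C@@H]2O)nn1`: 7580 nM

Going by the values given here, with only these two numbers, compound 2 has no place apart from compound 1: the one measured step, a 1.6-fold lower number from compound 1 to compound 2 (0.21 log units; within the scatter), lies within the scatter. Compound 3 `CCCCCCCCCCCCCCCCCCn1cc(COC[C@@H]2OC[C@H](N)[C@H]2O)nn1` is the stereoisomer to consider next: the two compounds have the same atoms and bonds and differ only in configuration as drawn: 1 of 3 stereo elements differ; a stereocentre at a saturated ring carbon is drawn S in compound 2 and R in compound 3. Among the compounds with values here, the measured step concerns the chain and not a stereocentre, so it bears on this change only indirectly, and no measured pair shows what a change of configuration does in this assay. Without such evidence, no step beyond the scatter is expected in either direction, although a larger one cannot be ruled out. The estimated step is a 1.1-fold higher number from compound 2 to compound 3 (0.02 log units; within the scatter). For compound 3 the expected value is 8000 nM, with an estimated range of 3500 nM to 18000 nM.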

Compound 3, half-maximal inhibitory concentration: 1930 nM
Compound 3: the middle estimate sits 4.1-fold (0.62 log units) above what was measured; the whole stated range lies above it.
By their numbers in this assay, from the lowest: compound 3; then compounds 2 and 1 (each within the scatter of the next).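

In this assay, the configuration at a saturated ring carbon turns out to matter: drawing this stereocentre R in place of S gives a 3.9-fold lower number from compound 2 to compound 3 (0.59 log units; beyond the scatter). Of the two steps now available, only this one lies beyond the scatter, whereas the change in the chain gave a 1.6-fold lower number from compound 1 to compound 2 (0.21 log units; within the scatter). The step can be assigned to this single stereocentre, because nothing else in the structure changes: the fact that compounds 2 and 3 differ only in the configuration as drawn

On these data alone, what remains open is whether the same change of configuration would have a similar effect on the shorter chain of compound 1, and what the remaining stereo elements contribute. The compounds shown also leave open how the shared core would respond if a hydroxyl or a carboxylic acid stood in place of the amine.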